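Working notes: one added isopropyl on compound 1

The source may report more compounds than this note shows. Statements on the series, on what has been measured and on what is new or still open speak of the compounds shown alone.

Measured in a functional assay on HeLa cells (Homo sapiens) for inhibition, read by MTT assay, with a stated time of 72 h; on this read-out lower numbers stand for stronger inhibition and higher numbers for weaker inhibition:
- compound 1 `CCc1ccc(C(C)C)cc1C(=O)/C=C/C(=O)O`: 4890 nM
- compound 2 `CC(C)c1ccc(C(C)C)c(C(=O)/C=C/C(=O)O)c1`: 4750 nM

Among the measured compounds shown here, compound 1, at 4890 nM, stands level with compound 2, the only other measured compound, and no order can be drawn between them. For the measured compounds named here, the single measured step is a 1.0-fold lower number from compound 1 to compound 2 (0.01 log units; within the scatter). That step is methyl in place of hydrogen on a saturated chain carbon bound to an aromatic carbon and a saturated chain carbon.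

The next compound is compound 3 `CCc1c(C(=O)/C=C/C(=O)O)cc(C(C)C)cc1C(C)C`. Its difference from compound 1 is isopropyl in place of hydrogen on an aromatic carbon, which is isopropyl in place of hydrogen on an aromatic carbon, ortho to an ethyl group. Going by the values given here, no measured step covers a change on an aromatic carbon, and the step to compound 2 at 4750 nM is only a loose guide. On that thin evidence, no step beyond the scatter is expected in this assay, and no direction can be argued. For compound 3 the expected step is a 1.1-fold lower number from compound 1 to compound 3 (0.04 log units; within the scatter). The estimated value for compound 3 is 4500 nM, with an expected range from 2000 nM to 10000 nM.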

Compound 3, half-maximal inhibitory concentration: 7610 nM
Estimate against measurement, compound 3: 1.7-fold (0.23 log units) below, and the stated range covers the measured number.
By their numbers in this assay, from the lowest: compounds 2, 1 and 3 (each within the scatter of the next).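

In this assay, isopropyl in place of hydrogen on an aromatic carbon, ortho to an ethyl group, gives a 1.6-fold higher number from compound 1 to compound 3 (0.19 log units; within the scatter), so compound 3 at 7610 nM stands level with compound 1 at 4890 nM. Among the compounds shown here, this is the first reading on the six-membered aromatic ring itself, as the earlier step, a 1.0-fold lower number from compound 1 to compound 2 (0.01 log units; within the scatter), concerned only a saturated chain carbon, and neither single change moves the number beyond the scatter in this assay. No measurement on hand accounts for this result.

The compounds shown carry only ethyl and isopropyl groups on the ring, so it remains open whether this aromatic carbon would give a similar number with an amine or a hydroxyl group in place of the isopropyl. Also open, as far as these compounds go, is whether a single added group at another ring carbon, or a longer chain in place of the ethyl group, would stay within the scatter of compound 1.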